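The source may report more compounds than this note shows. Statements on the series, on what has been measured and on what is new or still open speak of the compounds shown alone.

Measured compounds in an assay for inhibition of serine/threonine-protein kinase Sgk1 (Homo sapiens), with stated times of 30 min and 60 min, in the presence of a further agent that is not named here; on this read-out lower numbers stand for stronger inhibition and higher numbers for weaker inhibition:
- compound 1, `O=C(N[C@@H]1CCNC1)c1cc(-c2ccc(NS(=O)(=O)c3cccc(Cl)c3Cl)cc2)nc2[nH]ncc12`: < 1 nM
- compound 2, `CC(C)N1CC[C@H](NC(=O)c2cc(-c3ccc(NS(=O)(=O)c4cccc(Cl)c4Cl)cc3)nc3[nH]ncc23)C1`: 4 nM
- compound 3, `CCOc1nc(-c2ccc(NS(=O)(=O)c3cc(Cl)ccc3F)cc2)nc2[nH]nc(C)c12`: 23 nM

The value of compound 1 is a limit of the assay, not a number; it sits at the limit of < 1 nM in this assay, at which 1 of the 3 values shown sits. Among the numbers shown, compound 3 gives 23 nM, the higher of the two. Compound 2 gives 4 nM, which is the nearer of the other entries and clearly lower.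

Compound 4, `Cc1n[nH]c2nc(-c3ccc(NS(=O)(=O)c4cc(Cl)ccc4F)cc3)nc(OCCCO)c12`, differs from compound 3 in one place: hydroxymethyl in place of hydrogen on a saturated chain carbon, two bonds along the chain from an oxygen on an aromatic ring. Going by the values given here, the only measured step is an at least 4.0-fold higher number from compound 1 to compound 2 (0.60 log units; beyond the scatter), which concerns a change on an amide-type nitrogen, a position and a kind of change with no parallel to the chain extension at the ether oxygen in compound 4. Among the compounds with values here, no measured step therefore bears directly on this change, and no direction can be taken from the data.

The expectation for compound 4 is a step within the scatter, a 1.1-fold higher number from compound 3 to compound 4 (0.04 log units; within the scatter). Compound 4 is estimated at 25 nM, with a range from 8 nM to 75 nM.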

Compound 4, half-maximal inhibitory concentration: 2 nM
Estimate against measurement, compound 4: 13-fold (1.10 log units) above, outside the stated range (below it).
By their numbers in this assay, from the lowest: compounds 4 and 2 (each within the scatter of the next); then compound 3. At a limit, below all of these: compound 1.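

Ethoxy to 3-hydroxypropoxy is the first measured change at this position, and in this assay it gives a 12-fold lower number from compound 3 to compound 4 (1.06 log units; beyond the scatter) as the result of adding hydroxymethyl on a saturated chain carbon, two bonds along the chain from an oxygen on an aromatic ring. The earlier single-place step concerned only an amide-type nitrogen, so it gave no reading of this chain. This position therefore responds strongly to a small addition of 2 heavy atoms, although nothing measured here accounts for the step.

The compounds shown leave open whether the hydroxyl or the longer chain carries this step, a question that propoxy and 2-hydroxyethoxy groups would separate. Also open, going by these compounds, is whether a 3-aminopropoxy group or a carboxylic acid on the chain would keep the same level of inhibition.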